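A few compounds are considered here, and "the series" means these few. Any claim that something is new, unique, unknown or untested is made for them only; others in the source may bear on it.

Measured compounds:
- compound 1, `O=S(=O)(Nc1nccs1)c1ccc2c(c1)OCC[C@H]2c1ccc(C(F)(F)F)cc1-n1ccnn1`: 2.3
- compound 2, `Cn1nccc1-c1cc(C(F)(F)F)ccc1[C@H]1CCOc2cc(S(=O)(=O)Nc3ncccn3)ccc21`: 3.7
- compound 3, `O=S(=O)(Nc1nccs1)c1ccc2c(c1)OCC[C@@H]2c1ccc(C(F)(F)F)cc1-n1ccnn1`: 2.3

In a physicochemical assay for lipophilicity (a lower number here means a more polar compound, a higher number a more lipophilic compound), compound 1 gives 2.3. For the measured compounds named here, compound 1 stands level with compound 3 on these digits, and the two together are the lowest of the three numbers; the one step that connects compound 1 to another measured compound, no change at the digits printed from compound 1 to compound 3 (within the scatter), is no change within the scatter, which rests on (the fact that compounds 1 and 3 differ only in the configuration as drawn). Going by the values given here, compound 2 gives 3.7 in this assay, a number well above compound 1 and beyond the scatter, but compound 2 differs from compound 1 in more than one place, so no single step between them is computed.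

The next compound is compound 4, `O=S(=O)(Nc1nccs1)c1ccc2c(c1)OCC[C@H]2c1ccc(C(F)(F)F)cc1-c1nccs1`, which is not yet measured in this assay. It differs from compound 1 in one place: 1,3-thiazol-2-yl in place of 1H-1,2,3-triazol-1-yl on an aromatic carbon. Among the compounds with values here, none of the measured steps bears on this change; the step from compound 1 to compound 3 concerns configuration only, and its size of no change says nothing about a new ring in this place. The expectation for compound 4 therefore rests on the structural change alone, and an upward step, a number 0.90 log units higher from compound 1 to compound 4 (beyond the scatter), is estimated. In this assay compound 4 is expected to give about 3.2, with a range from 2.6 to 3.8.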

Compound 4, distribution coefficient: 3.3
Compound 4: middle estimate off by 0.10 log units, on the low side; measured number inside the range.
By their numbers in this assay, from the lowest: compounds 1 and 3 (each within the scatter of the next); then compound 4; then compound 2.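

In this assay, 1,3-thiazol-2-yl in place of 1H-1,2,3-triazol-1-yl on this aromatic carbon gives a number 1.00 log units higher from compound 1 to compound 4 (beyond the scatter), although both rings are five-membered and aromatic with 5 heavy atoms each, and the entering ring has 2 hydrogen-bond acceptors where the leaving ring has 3. The earlier compounds offered only no change at the digits printed from compound 1 to compound 3 (within the scatter), a step in configuration at a saturated ring carbon, so this is the first sign that the number in this assay responds to a change among the compounds shown, and that the place ortho to a large group and meta to a trifluoromethyl group is where it does so. Nothing known about these compounds explains why this exchange of rings moves the number as it does.

The compounds shown leave open whether the same step would appear in the opposite configuration at the saturated ring carbon, as drawn in compound 3. They also leave open how this assay would read with a group of another kind at this aromatic carbon, such as an amine or a carboxylic acid.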